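This account rests on a few compounds, and the source may have more. Where it says the series, first, only, none or still open, it means among the compounds named here.

Of the compounds shown here, three have been measured in a functional assay for inhibition, with Homo sapiens as the target; a higher number here means a weaker inhibitor, a lower number a stronger inhibitor. Compound 1 `C=CCn1nc(CCC)c2c(C)nc(CCC)n2c1=O` gives 29000 nM in this assay. Compound 2 `Cc1nc(C)n2c(Nc3cc[nH]n3)nccc12` gives 53000 nM in this assay, and compound 3 `C=CCSc1nncc2cnc(C)n12` gives 61000 nM. Compound 1 has the lowest of the three numbers, but its gap to compound 2 lies within the usual scatter of repeated measurements, so those two cannot be told apart; only its gap to compound 3 lies beyond the scatter. All three numbers sit far up the scale, meaning none of these compounds inhibits strongly.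

Compound 4 `C=CCn1ncc2c(C)nc(CCC)n2c1=O` has not yet been measured. It differs from compound 1 in one place: hydrogen in place of propyl on an aromatic carbon. Going by the values given here, no measured pair shows this kind of change, so nothing here says how large a step to expect. Taking a three-carbon chain away from a small core usually does not help, so a modest rise in the number is expected, as a 2.1-fold higher number from compound 1 to compound 4 (0.32 log units; beyond the scatter). For compound 4 the expected value is 60000 nM, with a plausible range from 20000 nM to 200000 nM.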

Compound 4, half-maximal inhibitory concentration: 40000 nM
Compound 4: middle estimate off by 1.5-fold (0.18 log units), on the high side; low and high end bracket the measured number.
By their numbers in this assay, from the lowest: compounds 1, 4, 2 and 3 (each within the scatter of the next, the first and the last beyond it).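

Replacing propyl with hydrogen on this aromatic carbon gives a 1.4-fold higher number from compound 1 to compound 4 (0.14 log units; within the scatter) in this assay, so compound 1 and compound 4 cannot be told apart. Going by these compounds alone, this is the first pair that differs in one place, and it shows that the propyl group at this position makes no difference that this measurement can detect. Nothing available explains this result.

A single pair cannot say whether other groups are tolerated equally at this carbon: a methyl, a longer chain such as hexyl, an amine or a carboxylic acid might leave the number unchanged or shift it beyond the scatter. From the compounds shown here alone, it also remains open whether any group here could bring the number far down the scale, where a strong inhibitor would sit.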